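Notes on the series: the step from compound 3 to compound 4

This account rests on a few compounds, and the source may have more. Where it says the series, first, only, none or still open, it means among the compounds named here.

Measured in a functional assay on PC-3 cells (Homo sapiens) for cytotoxicity, read by MTT assay, with a stated time of 48 h; a lower number here means a stronger inhibitor, a higher number a weaker inhibitor:
compound 1 `CC1=NN(C(=O)c2ccc(C)cc2)C(c2cc(Br)ccc2O)C1` gives 41200 nM
compound 2 `CCN(CC)CC(=O)N1N=C(C)CC1c1ccccc1O` gives 25900 nM
compound 3 `CCN(CC)CC(=O)N1N=C(C)CC1c1ccccc1OC(C)=O` gives 51200 nM

Compound 3 sits at the top of these three numbers, yet the step of a 2.0-fold higher number from compound 2 to compound 3 (0.30 log units; within the scatter) lies within the scatter, and the gap between compound 3 and compound 1 is narrower still, so the three numbers are not separated. Compound 4 `CC(=O)Oc1ccccc1C1CC(C)=NN1C(=O)CN1CCC(O)CC1` differs from compound 3 by 4-hydroxypiperidin-1-yl in place of diethylamino on a saturated chain carbon bound to a carbonyl carbon. Within the data shown here, no measured step touches this part of the molecule; the only single-point step known changes the ring oxygen substituent, and compound 1 differs from the others in several places at once. With nothing to point either way, the step of a 1.0-fold lower number from compound 3 to compound 4 (0.01 log units; within the scatter) is expected to stay within the scatter. Compound 4 is therefore estimated at 50000 nM, with a range from 20000 nM to 130000 nM in this assay.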

Compound 4, half-maximal inhibitory concentration: 25600 nM
Compound 4: the middle estimate sits 2.0-fold (0.29 log units) above what was measured, within the range that was stated.
By their numbers in this assay, from the lowest: compounds 4, 2, 1 and 3 (each within the scatter of the next).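

Among these compounds, the first measured change at this place, on a saturated chain carbon bound to a carbonyl carbon, gives a 2.0-fold lower number from compound 3 to compound 4 (0.30 log units; within the scatter) in this assay. Replacing open diethylamino with 4-hydroxypiperidin-1-yl, which adds a six-membered non-aromatic ring and a hydrogen-bond donor, therefore does not separate the two numbers. No available evidence accounts for this result.

Still open, going by these compounds, is whether piperidin-1-yl without the hydroxyl, morpholin-4-yl or a carboxylic acid on this chain would move the number beyond the scatter. A longer chain carrying the same 4-hydroxypiperidin-1-yl also remains an open question.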